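A few compounds are considered here, and "the series" means these few. Any claim that something is new, unique, unknown or untested is made for them only; others in the source may bear on it.

Measured so far:
compound 1, `Cc1cc(C)n2nccc2n1`: 60.3 mg/kg
compound 2, `Cc1cc(C)n2ncc(F)c2n1`: 40.2 mg/kg

Both numbers come from a functional assay on the whole organism with Rattus norvegicus as the target; a higher number here means that more compound is needed for the effect, a lower number that less compound is needed. On the numbers shown, compound 2 sits nearest compound 1, and the step of a 1.5-fold lower number from compound 1 to compound 2 (0.18 log units; within the scatter) lies within the scatter, so the two compounds cannot be told apart. Compound 3, `Cc1cc(C)n2ncc(I)c2n1`, is not yet measured; the change is iodo in place of fluoro on an aromatic carbon. Among the measured compounds shown here, the one measured step, fluoro in place of hydrogen, bears only loosely on iodo in place of fluoro, and it was small. No step beyond the scatter is therefore expected in this assay; the expected step is a 1.0-fold lower number from compound 2 to compound 3 (0.00 log units; within the scatter). Compound 3 is estimated at 40 mg/kg, within a range from 15 mg/kg to 110 mg/kg.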

Compound 3, dose for half-maximal effect: 39.1 mg/kg
Estimate against measurement, compound 3: 1.0-fold (0.01 log units) above; the measured number falls inside the stated range.
By their numbers in this assay, from the lowest: compounds 3, 2 and 1 (each within the scatter of the next).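

In this assay the change from fluoro to iodo gives a 1.0-fold lower number from compound 2 to compound 3 (0.01 log units; within the scatter) on this aromatic carbon, and iodo in place of hydrogen gives a 1.5-fold lower number from compound 1 to compound 3 (0.19 log units; within the scatter) on the same carbon. This carbon has now carried hydrogen, fluoro and iodo, and the three compounds cannot be told apart, so even a single iodine atom in place of fluorine leaves no readable difference. No measured evidence here bears on the reason for this.

As far as these compounds go, whether an amine, a carboxylic acid or a longer chain on this carbon would shift the number beyond the scatter remains open. So does the effect of changes elsewhere on the shared core.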